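Swapping the methoxyphenyl for a dichlorohydroxyphenyl

This account rests on a few compounds, and the source may have more. Where it says the series, first, only, none or still open, it means among the compounds named here.

Compound 1 `COc1ccc(/C=N/NC(=O)CSc2nnc(-c3ccncc3)o2)cc1`: 15800 nM
Compound 2 `COc1cccc(/C=N/NC(=O)CSc2nnc(-c3ccncc3)o2)c1`: 9170 nM

In a functional assay on HepG2 cells (Homo sapiens) for cytotoxicity, read by MTT assay, with a stated time of 48 h (on this read-out higher numbers stand for weaker inhibition and lower numbers for stronger inhibition), compound 2 gives 9170 nM and compound 1 gives 15800 nM; the step of a 1.7-fold lower number from compound 1 to compound 2 (0.24 log units; within the scatter) is within the scatter, so compound 2 stands lowest of two numbers only by a margin that carries no weight. Compound 3 `O=C(CSc1nnc(-c2ccncc2)o1)N/N=C/c1cc(Cl)cc(Cl)c1O` arises from compound 2 by 3,5-dichloro-2-hydroxyphenyl in place of 3-methoxyphenyl on a carbon with a double bond to nitrogen. Within the data shown here, the single measured step only moved the methoxy group around its ring and stayed within the scatter, so it gives little guidance for this larger change. For compound 3 in this assay the expected step is a 1.7-fold lower number from compound 2 to compound 3 (0.22 log units; within the scatter), an estimate of 5500 nM with a range from 1500 nM to 25000 nM.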

Compound 3, half-maximal inhibitory concentration: 3260 nM
Compound 3: middle estimate off by 1.7-fold (0.23 log units), on the high side; low and high end bracket the measured number.
By their numbers in this assay, from the lowest: compound 3; then compounds 2 and 1 (each within the scatter of the next).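

In this assay the group on the carbon with a double bond to nitrogen now produces steps beyond the scatter, unlike moving the methoxy group around its ring: a 2.8-fold lower number from compound 2 to compound 3 (0.45 log units; beyond the scatter) and a 4.8-fold lower number from compound 1 to compound 3 (0.69 log units; beyond the scatter) for the other methoxy compound. So this position does respond to a change of substituents on the ring, and 3,5-dichloro-2-hydroxyphenyl is the better of the groups shown here. Chlorine and hydroxy enter together, so their separate shares stay open, as does how an amine or a carboxylic acid on this ring would read. Nothing available explains the drop in the number.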